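Chloro to fluoro on the aryl thiazole of an acid series

This account rests on a few compounds, and the source may have more. Where it says the series, first, only, none or still open, it means among the compounds named here.

Compound 1 `Cc1nc(-c2cccs2)sc1COc1ccc2c(c1)OCC2CC(=O)O` carries a thiophene on the thiazole, and in a functional assay on CHO cells for agonist activity at Free fatty acid receptor 1 (Homo sapiens), read by FLIPR and calcium flux (on this read-out higher numbers stand for an effect only at larger amounts of compound and lower numbers for an effect already at smaller amounts), compound 1 stands at "not determined" (no result reported), with no number behind it. Going by the values given here, compound 2 `Cc1nc(-c2ccc(Cl)cc2)sc1COc1ccc2c(c1)OCC2CC(=O)O` carries a 4-chlorophenyl in the same place, and in this assay compound 2 gives 85.6 nM, the only number available in this set, so it serves as the sole anchor. Compound 3 `Cc1nc(-c2ccc(F)cc2)sc1COc1ccc2c(c1)OCC2CC(=O)O` differs from compound 2 only in that fluoro replaces chloro on an aromatic carbon (fluoro in place of chloro on an aromatic carbon). Among the compounds with values here, no measured pair shows what this exchange does here, so the expectation rests on compound 2 alone. A modest loss is expected, with a step of a 1.9-fold higher number from compound 2 to compound 3 (0.27 log units; within the scatter) that may not clearly exceed the usual scatter. Compound 3 is therefore estimated at 160 nM in this assay, with a range from 60 nM to 450 nM.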

Compound 3, half-maximal effective concentration: 48.7 nM
Compound 3: middle estimate off by 3.3-fold (0.52 log units), on the high side; measured number outside the range, below it.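

In this assay, the exchange of 4-chlorophenyl for 4-fluorophenyl gives a 1.8-fold lower number from compound 2 to compound 3 (0.24 log units; within the scatter), so the two halogens cannot be told apart at this place on the aromatic ring. Going by these compounds alone, this is the first measured pair, and it shows that either chloro or fluoro at this place on the phenyl ring is compatible with a value in the same range on this read-out. Nothing available bears on a reason for this result.

Going by these compounds, what a methoxy group, a trifluoromethyl group or a nitrile would give at this place remains open, as does the result for a phenyl ring with only hydrogen there. Compound 1 stands at "not determined" (no result reported), so its thiophene cannot be set against either of the halogen-bearing phenyl groups.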